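This account rests on a few compounds, and the source may have more. Where it says the series, first, only, none or still open, it means among the compounds named here.

Measured in an ADME assay on HepG2 2.2.15 cells (Homo sapiens) for cytotoxicity; a higher number here means that more compound is tolerated, a lower number that less compound is tolerated:

Compound 1 `COC(=O)CCCCNc1ncc(C(Oc2ccc3cc(Br)ccc3c2)c2ccc(Cl)cc2)s1`, reported as "not toxic" (no number reported).
Compound 2 `O=C(Nc1ncc(C(Oc2ccc3cc(Br)ccc3c2)c2ccc(Cl)cc2)s1)C1CCOCC1`, reported as "not toxic" (no number reported).
Compound 3 `COc1ccc(C(=O)Nc2ncc(C(Oc3ccc4cc(Br)ccc4c3)c3ccc(Cl)cc3)s2)cc1`, reported as > 50000 nM, which is a limit of this assay and not a number.

Compound 3 therefore stands at the edge of what this assay can resolve: its half-maximal cytotoxic concentration is given only as a limit, and it is the one entry of the three that carries any figure at all (the limit of > 50000 nM in this assay, at which 1 of the 3 values shown sits). Within the data shown here, compound 1 and compound 2 are described only as not toxic, without a number, so no step between measured compounds can be sized here.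

Compound 4 `O=C(Nc1ncc(C(Oc2ccc3cc(Br)ccc3c2)c2ccc(Cl)cc2)s1)c1ccc(Br)cc1` differs from compound 3 in one place: bromo in place of methoxy on an aromatic carbon. Among the measured compounds shown here, with nothing but a limit on one side and no measured step to lean on, no shift beyond the usual scatter is expected from compound 3 to compound 4, and the result is most likely to come back as a limit again. Compound 4 is accordingly estimated at 50000 nM, between 20000 nM and 120000 nM, which means an expected step of a number no higher from compound 3 to compound 4 (the limit leaves the size open).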

Compound 4, half-maximal cytotoxic concentration: > 50000 nM
Compound 4: a limit, no number (the forecaster's own chance of this, stated with the estimate: 70%); the middle value sits exactly at the limit.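

Compound 4 comes back at > 50000 nM, which is a limit and not a number. Among these compounds, compound 3 also stands at a limit, so no step from compound 3 to compound 4 can be read. The compounds shown leave open at what concentration, if any, they become toxic to these cells.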